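A few compounds are considered here, and "the series" means these few. Any claim that something is new, unique, unknown or untested is made for them only; others in the source may bear on it.

Compound 1 `O=C(CN[C@H]1CCN(S(=O)(=O)Cc2ccccc2)C1)N1CCN(Cc2ccccc2Cl)CC1`: 9000 nM
Compound 2 `O=C(CN[C@H]1CCN(S(=O)(=O)Cc2ccccc2)C1)N1CCN(Cc2ccc(F)cc2)CC1`: 14300 nM
Compound 3 `O=C(CN[C@H]1CCN(S(=O)(=O)Cc2ccccc2)C1)N1CCN(Cc2ccc(Cl)cc2Cl)CC1`: 4300 nM

These values come from a functional assay on K562 cells (Homo sapiens) for cytotoxicity, read by MTT assay, with a stated time of 48 h; on this read-out higher numbers stand for weaker inhibition and lower numbers for stronger inhibition. Compound 3 has the lowest number of the three, and its gaps to both of the others lie beyond the scatter. The unmeasured compound 4 `COc1cccc(CN2CCN(C(=O)CN[C@H]3CCN(S(=O)(=O)Cc4ccccc4)C3)CC2)c1` keeps the shared core and differs from compound 3 in one group: 3-methoxyphenyl in place of 2,4-dichlorophenyl on a saturated chain carbon bound to an amine nitrogen in a ring. Put simply, 3-methoxyphenyl takes the place of 2,4-dichlorophenyl on a saturated chain carbon bound to an amine nitrogen in a ring.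

Within the data shown here, two measured steps bear on this change, and both are modest. Putting chloro in place of hydrogen on an aromatic carbon gave a 2.1-fold lower number from compound 1 to compound 3 (0.32 log units; beyond the scatter), and exchanging 4-fluorophenyl for 2,4-dichlorophenyl gave a 3.3-fold lower number from compound 2 to compound 3 (0.52 log units; beyond the scatter). The remaining step, a 1.6-fold higher number from compound 1 to compound 2 (0.20 log units; within the scatter), stays within the scatter. Compound 4 gives up the 2,4-dichlorophenyl group that only compound 3 carries, so its number is expected to return towards those of compound 1 and compound 2. Among the measured compounds shown here, no measured compound carries a methoxy group, however, so this comparison is only a loose guide. The estimated change is a 2.6-fold higher number from compound 3 to compound 4 (0.41 log units; beyond the scatter). For compound 4 the estimated value is 11000 nM, with an expected range from 5500 nM to 22000 nM.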

Compound 4, half-maximal inhibitory concentration: 60800 nM
Beside the measured number, compound 4's estimate is 5.5-fold (0.74 log units) below it; the whole stated range lies below it.
By their numbers in this assay, from the lowest: compound 3; then compounds 1 and 2 (each within the scatter of the next); then compound 4.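

Among these compounds, the group at this place on the shared core can shift the result much further than the earlier compounds suggested. In this assay, 3-methoxyphenyl gives the weakest inhibition of the four compounds, with a 14-fold higher number from compound 3 to compound 4 (1.15 log units; beyond the scatter), a 6.8-fold higher number from compound 1 to compound 4 (0.83 log units; beyond the scatter) and a 4.3-fold higher number from compound 2 to compound 4 (0.63 log units; beyond the scatter), whereas the widest step among the halogen-bearing groups was a 3.3-fold lower number from compound 2 to compound 3 (0.52 log units; beyond the scatter). The data in hand offer no measurement that explains this loss of activity.

The compounds shown leave open whether the higher number comes from the methoxy group itself, from its place on the phenyl ring or from the absence of chloro: compound 4 is the only compound with a methoxy group and, unlike compound 1 and compound 3, has no chloro. On these data alone, how an unsubstituted phenyl, or a phenyl carrying a hydroxyl, methyl or trifluoromethyl group, would compare in this assay also remains open, and such groups could show whether the sharp change seen with compound 4 is specific to methoxy.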